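Chloro in place of trifluoromethoxy on the aryl isoxazole

A few compounds are considered here, and "the series" means these few. Any claim that something is new, unique, unknown or untested is made for them only; others in the source may bear on it.

Compound 1 `FC(F)(F)Oc1ccc(-c2cc(COc3ccccc3-c3nc4ccccc4s3)on2)cc1`: in a functional assay on COLO 205 cells (Homo sapiens) for cytotoxicity, read by MTT assay, with a stated time of 24 h (on this read-out higher numbers stand for weaker inhibition and lower numbers for stronger inhibition), compound 1 gives 19900 nM.
Compound 2 `FC(F)(F)c1cccc(-n2cc(COc3ccccc3-c3nc4ccccc4s3)nn2)c1`: in this assay compound 2 gives 10800 nM.

Both numbers are weak, and compound 1 sits within the usual scatter of compound 2, so the two cannot be told apart in this assay. Compound 3 `Clc1ccc(-c2cc(COc3ccccc3-c3nc4ccccc4s3)on2)cc1` is not yet measured. It differs from compound 1 by chloro in place of trifluoromethoxy on an aromatic carbon. Among the compounds with values here, no measured pair shows this change, so nothing here says how large a step to expect; without such a step, the expected move in this assay is none beyond the scatter. Compound 3 is therefore expected at 15000 nM, between 5000 nM and 45000 nM, a step of a 1.3-fold lower number from compound 1 to compound 3 (0.12 log units; within the scatter).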

Compound 3, half-maximal inhibitory concentration: 16500 nM
Compound 3: the middle estimate sits 1.1-fold (0.04 log units) below what was measured, within the range that was stated.
By their numbers in this assay, from the lowest: compounds 2, 3 and 1 (each within the scatter of the next).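

In this assay the change from 4-(trifluoromethoxy)phenyl to 4-chlorophenyl gives a 1.2-fold lower number from compound 1 to compound 3 (0.08 log units; within the scatter) and so stays within the scatter. At this place on the aromatic ring, a single chlorine atom therefore reads the same as the five heavy atoms of trifluoromethoxy, and the numbers remain weak. No evidence here bears on the reason for this.

The compounds shown leave open whether an amine or a carboxylic acid at this place would move the number beyond the scatter. They also leave open whether any change here can give a stronger compound.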